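The source may report more compounds than this note shows. Statements on the series, on what has been measured and on what is new or still open speak of the compounds shown alone.

Compound 1 `COc1ccc(NC(=O)[C@@H]2CC=C(CCC=C(C)C)C[C@H]2c2ccccc2)cc1` was tested in an assay on isolated protein for inhibition of Apoptosis regulator Bcl-2 (Homo sapiens), read by fluorescence polarization, with stated times of 5 min and 10 min; on this read-out higher numbers stand for weaker inhibition and lower numbers for stronger inhibition. In this assay compound 1 gives > 23000 nM, which is a limit of the assay rather than a number. Compound 2 `CC1(C)CCCC2=C1C[C@@H](C(=O)O)[C@H](c1ccccc1)C2` gives > 23000 nM, also a limit. Compound 3 `COC(=O)c1ccc(NC(=O)[C@H]2CC=C(CCC=C(C)C)C[C@@H]2c2ccccc2)cc1` gives > 23000 nM, again a limit. Compound 1 therefore cannot be placed above or below the others, since the limit of > 23000 nM in this assay, at which 3 of the 3 values shown sit, covers every value shown. Compound 4 `COC(=O)CCNC(=O)[C@@H]1CC=C(CCC=C(C)C)C[C@H]1c1ccccc1` has not yet been measured. It differs from compound 1 by 2-(methoxycarbonyl)ethyl in place of 4-methoxyphenyl on an amide-type nitrogen. Among the measured compounds shown here, with no measured step to give a direction, no change beyond the scatter is expected, and the step from compound 1 to compound 4 is estimated as a step that the limit leaves unreadable from compound 1 to compound 4. Compound 4 is expected at 30000 nM, between 10000 nM and 100000 nM.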

Compound 4, inhibition constant: > 23000 nM
Compound 4 gave a limit, no number; the forecaster's own chance of this, stated with the estimate: 85%; the middle value lies beyond the limit too.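

No step can be read between compound 1 and compound 4, because both sit at the same limit: the limit of > 23000 nM in this assay, at which 4 of the 4 values shown sit. The compounds shown leave open whether 2-(methoxycarbonyl)ethyl in place of 4-methoxyphenyl changes inhibition at all.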